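This account rests on a few compounds, and the source may have more. Where it says the series, first, only, none or still open, it means among the compounds named here.

Working notes on the series. Compound 1 `OCCc1cc2nn(-c3ccccc3)cc2cn1` and compound 2 `CCCCc1cc2nn(-c3ccccc3)cc2cn1` share one core and differ only in the chain on it. In a functional assay on K562 cells (Homo sapiens) for inhibition, read by fluorescence, with a stated time of 72 h (on this read-out lower numbers stand for stronger inhibition of growth and higher numbers for weaker inhibition of growth), compound 1 gives only a limit of the assay, > 100000 nM. In this assay, among the measured compounds shown here, compound 2 gives 6700 nM, the only actual number in the set. The other value shown is the limit (the limit of > 100000 nM in this assay, at which 1 of the 2 values shown sits). For the measured compounds named here, the single measured step, an at least 14-fold lower number from compound 1 to compound 2 (1.17 log units; beyond the scatter), shows that the chain at this position is not indifferent to growth inhibition.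

Compound 3 `c1ccc(-n2cc3cnccc3n2)cc1` removes the chain altogether: hydrogen in place of butyl on an aromatic carbon. Going by the values given here, the one measured step bears on the same position, but it exchanges one chain for another rather than removing it, so it gives direction only loosely. Since the step from compound 1 to compound 2 was large, the bare core is expected to lose rather than gain, and the step from compound 2 to compound 3 is expected at a 4.5-fold higher number from compound 2 to compound 3 (0.65 log units; beyond the scatter). For compound 3 in this assay the estimate is 30000 nM, within a range of 8000 nM to 100000 nM, with a fair chance that only a limit is reported.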

Compound 3, concentration for 50% growth inhibition: > 100000 nM
Compound 3: only a limit was reported; the forecaster's own chance of this, stated with the estimate: 35%; middle value at least 3.3-fold (0.52 log units) away from the limit.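

In this assay, hydrogen in place of butyl on this aromatic carbon gives an at least 14-fold higher number from compound 2 to compound 3 (1.17 log units; beyond the scatter), so the only measurable growth inhibition in the set requires a chain here and does not come from the shared core alone. As far as these compounds go, compound 3 gives only a limit of the assay, > 100000 nM, so the true size of this step stays open. The step between compound 1 and compound 3 cannot be read, which leaves 2-hydroxyethyl and hydrogen unordered, and compound 2 remains the only compound with an actual number: the limit of > 100000 nM in this assay, at which 2 of the 3 values shown sit.

Still open, from the compounds shown here alone, is whether the gain with butyl follows the length of the chain or the absence of the hydroxy group, which a shorter chain such as methyl, a longer chain such as hexyl, or a butyl chain ending in an amine or a carboxylic acid would help to separate. Also open, going by these compounds, is whether a ring group such as cyclohexyl on this aromatic carbon would keep, lose or improve on the value of compound 2.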